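From Methoxy to Bromo on an Aromatic Carbon

This account rests on a few compounds, and the source may have more. Where it says the series, first, only, none or still open, it means among the compounds named here.

Compound 1 `Cc1cccc(Nc2nccc(-c3ccc(Br)cc3)n2)c1`: 74600 nM
Compound 2 `COc1cccc(Nc2nccc(-c3ccc(F)cc3)n2)c1`: 128000 nM
Compound 3 `COc1ccc(-c2ccnc(Nc3cccc(OC)c3)n2)cc1`: 13900 nM

All three values come from a functional assay on HepG2 cells (Homo sapiens) for antiproliferative activity, read by MTT assay; on this read-out lower numbers stand for stronger inhibition and higher numbers for weaker inhibition. Among them, compound 3 has the lowest number, 13900 nM, and its gaps to compound 1 and compound 2 both lie beyond the scatter. The next compound to be measured is compound 4 `COc1cccc(Nc2nccc(-c3ccc(Br)cc3)n2)c1`. Its difference from compound 3 is bromo in place of methoxy on an aromatic carbon, which puts bromo in place of methoxy on an aromatic carbon.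

For the measured compounds named here, one measured step bears directly on this place on the molecule. Methoxy in place of fluoro gave a 9.2-fold lower number from compound 2 to compound 3 (0.96 log units; beyond the scatter), a modest step beyond the scatter. Taking the methoxy away again may therefore give back much of that difference, although bromo is not fluoro and no measured pair compares the two directly. Compound 4 shares its bromo group with compound 1, which gives 74600 nM. That is only a rough guide, since those two compounds also differ elsewhere. A higher number in this assay is therefore expected, with a step beyond the scatter, similar to or somewhat smaller than the measured one.

The expected change is a 4.0-fold higher number from compound 3 to compound 4 (0.60 log units; beyond the scatter). For compound 4 the estimated value is 55000 nM, with an expected range from 22000 nM to 130000 nM.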

Compound 4, half-maximal inhibitory concentration: 148000 nM
Compound 4: middle estimate off by 2.7-fold (0.43 log units), on the low side; measured number above the stated range.
By their numbers in this assay, from the lowest: compound 3; then compounds 1, 2 and 4 (each within the scatter of the next).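

In this assay, the methoxy group on the aromatic carbon para to a large group now stands apart from two halogens rather than one: replacing it with bromo gives a large step (an 11-fold higher number from compound 3 to compound 4 (1.03 log units; beyond the scatter)), comparable in size to the step seen when methoxy replaced fluoro (a 9.2-fold lower number from compound 2 to compound 3 (0.96 log units; beyond the scatter)), while exchanging fluoro for bromo stays within the scatter (a 1.2-fold higher number from compound 2 to compound 4 (0.06 log units; within the scatter)). Compounds 2 and 4 therefore cannot be told apart in this assay, so at this position the clear difference appears with methoxy and not with the choice between these two halogens. With bromo held fixed, methoxy in place of methyl elsewhere on the molecule also stays within the scatter (a 2.0-fold higher number from compound 1 to compound 4 (0.30 log units; within the scatter)), and no available measurement explains why any of these steps has the size it does.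

The compounds shown leave open whether the low number depends on methoxy itself or would also appear with a related group at this position, such as hydroxy, ethoxy or an amine. They also leave open whether the methoxy step would keep its size with methyl in place of the second methoxy group.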